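One Methoxy Fewer: Compound 4 Weighed Against Compound 2

The source may hold more compounds than are shown below. What is called first, only, known or untested is meant among the compounds shown, and "the series" means these compounds.

Measured compounds and values:
compound 1, `COc1ccc(-c2cc(/C=C/C(=O)c3ccc(N)cc3)[nH]n2)cc1`, 88%
compound 2, `COc1cc(-c2cc(/C=C/C(=O)c3ccc(N)cc3)[nH]n2)cc(OC)c1OC`, 91%
compound 3, `COc1ccc(C(=O)/C=C/c2cc(-c3cc(OC)c(OC)c(OC)c3)n[nH]2)cc1OC`, 97%

All three were tested in a functional assay on A498 cells (Homo sapiens) for cytotoxicity, read by sulforhodamine B assay, with a stated time of 48 h, tested at 0.01 uM; on this read-out lower numbers stand for a stronger effect and higher numbers for a weaker effect at the one concentration tested. Compound 2 stands second highest of the three numbers. Its nearest neighbour is compound 1, whose value lies within the scatter of that of compound 2. The furthest is compound 3, reached by the step of a number 6 percentage points higher from compound 2 to compound 3 (within the scatter), which replaces the 4-aminophenyl on the carbonyl carbon with 3,4-dimethoxyphenyl and still stays within the scatter.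

Compound 4, `COc1ccc(-c2cc(/C=C/C(=O)c3ccc(N)cc3)[nH]n2)cc1OC`, is not yet measured. It differs from compound 2 in one place: hydrogen in place of methoxy on an aromatic carbon. Within the data shown here, the one step measured so far, a number 6 percentage points higher from compound 2 to compound 3 (within the scatter), concerns the other end of the shared core and so bears only loosely on this change. Among the measured compounds shown here, compounds 1 and 2, which carry one and three methoxy groups on the same ring, give values within the scatter of each other, though they differ in more than one place and no single step joins them. On this basis no step beyond the scatter is expected for compound 4, so the expected step is a number 2 percentage points lower from compound 2 to compound 4 (within the scatter). The estimated value for compound 4 is 89%, with a range from 79% to 99%.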

Compound 4, a percentage reported as activity, at one concentration (the size of the read-out at that concentration, not a potency): 95%
Beside the measured number, compound 4's estimate is 6 percentage points below it; the range from low to high includes it.
By their numbers in this assay, from the lowest: compounds 1, 2, 4 and 3 (each within the scatter of the next).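

In this assay, replacing the methoxy with hydrogen on this aromatic carbon, ortho to a methoxy group, meta to a large group and meta to a methoxy group, gives a number 4 percentage points higher from compound 2 to compound 4 (within the scatter), so at this place the read-out does not separate methoxy from hydrogen. Compound 4 also supplies the single-change link that compounds 1 and 2 lacked: adding a methoxy to the one-methoxy ring gives a number 7 percentage points higher from compound 1 to compound 4 (within the scatter), so the one-, two- and three-methoxy rings are now joined by steps that each stay within the scatter. Nothing available here gives a measured reason for these small steps.

On these data alone, it remains open whether a group other than hydrogen or methoxy on this carbon, such as a hydroxyl, a chlorine or a longer ethoxy chain, would give a step beyond the scatter. Also open, as far as these compounds go, is whether the same methoxy change would behave alike with the 3,4-dimethoxyphenyl of compound 3 on the carbonyl carbon, or at a concentration other than the one read here.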